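This account rests on a few compounds, and the source may have more. Where it says the series, first, only, none or still open, it means among the compounds named here.

Compound 1 `C[C@@H](O[C@H]1CN2C(=O)C=C(c3ccc(CO)cc3)CC2[C@@H]1c1ccc(F)cc1)c1cc(C(F)(F)F)cc(C(F)(F)F)c1` and compound 2 `Cc1cc(C2=CC(=O)N3C[C@H](O[C@H](C)c4cc(C(F)(F)F)cc(C(F)(F)F)c4)[C@@H](c4ccc(F)cc4)C3C2)ccn1` share one core and differ only in the group on a double-bonded ring carbon. In an assay on CHO cells for displacement of a labelled ligand from Substance-P receptor (Homo sapiens), in the presence of a further agent that is not named here (a higher number here means a weaker inhibitor, a lower number a stronger inhibitor), compound 1 gives 23 nM, and in this assay compound 2 gives 34 nM. For the measured compounds named here, the step of a 1.5-fold higher number from compound 1 to compound 2 (0.17 log units; within the scatter) is within the scatter, so the two numbers cannot be told apart; compound 2 merely holds the larger of the two numbers measured so far, with compound 1 as its only neighbour.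

Compound 3 `C[C@@H](O[C@H]1CN2C(=O)C=C(c3cc[nH]c(=O)c3)CC2[C@@H]1c1ccc(F)cc1)c1cc(C(F)(F)F)cc(C(F)(F)F)c1` has not yet been measured. Against compound 2 it shows (a group of 7 heavy atoms (5 carbon, 1 nitrogen, 1 oxygen; one six-membered aromatic ring with 1 hetero atom) in place of a group of 7 heavy atoms (6 carbon, 1 nitrogen; one six-membered aromatic ring with 1 hetero atom), on a double-bonded ring carbon). Going by the values given here, the only measured step at this position, from compound 1 to compound 2, stayed within the scatter, and compound 3 again exchanges one six-membered aromatic group with one hetero atom for another, so the expected step of a 1.2-fold higher number from compound 2 to compound 3 (0.07 log units; within the scatter) is small, with no change beyond the scatter. Compound 3 is therefore estimated at 40 nM, in a range from 15 nM to 110 nM.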

Compound 3, half-maximal inhibitory concentration: 3.9 nM
Compound 3: the middle estimate sits 10-fold (1.01 log units) above what was measured; the measured number lies below the stated range.
By their numbers in this assay, from the lowest: compound 3; then compounds 1 and 2 (each within the scatter of the next).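

The pair of compound 1 and compound 2 could suggest that this position tolerates exchange freely, but in this assay the new group gives an 8.7-fold lower number from compound 2 to compound 3 (0.94 log units; beyond the scatter) and a 5.9-fold lower number from compound 1 to compound 3 (0.77 log units; beyond the scatter), both beyond the scatter. The step from compound 2 keeps the count of 7 heavy atoms and a six-membered aromatic ring with 1 hetero atom, yet the group that enters has 1 hydrogen-bond donor where the group that leaves has 0, so the number here does not follow ring type and heavy-atom count alone. Nothing available explains the gain.

The compounds shown cannot separate the contribution of the donor hydrogen from that of the carbonyl in the new group. Going by these compounds, a methyl group on its ring nitrogen, or an amine or a carboxylic acid on the aromatic ring, remains untested among them.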